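The compounds below may be only part of what the source reports. "The series", "measured", "known", "first", "only" and "open" are said of these compounds alone.

Compound 1 `CCOC(=O)C(C)Nc1cccc2c(S(=O)(=O)Nc3onc(C)c3C)cccc12` is the reference point of this series. Among the measured compounds shown here, in an assay on VSM-A10 cells for antagonist activity at Endothelin-1 receptor (Rattus norvegicus) (on this read-out lower numbers stand for stronger inhibition and higher numbers for weaker inhibition), compound 1 gives 400 nM, and this is the only number on record. Compound 2 `Nc1ccc(S(=O)(=O)Nc2noc3c2CCCC3)cc1` reaches only the limit of the assay, reported for compound 2 as > 32000 nM. For the measured compounds named here, that limit is the single piece of evidence on the measured side (the limit of > 32000 nM in this assay, at which 1 of the 2 values shown sits), and since compound 2 shares neither the core of compound 1 nor its substituent pattern, no step between measured compounds can be drawn from it.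

Compound 3 `CCCCCNc1cccc2c(S(=O)(=O)Nc3onc(C)c3C)cccc12` is the next compound to be measured. Its difference from compound 1 is a single change (pentyl in place of 1-(ethoxycarbonyl)ethyl on a nitrogen on an aromatic ring). The 1-(ethoxycarbonyl)ethyl group that leaves carries two hydrogen-bond acceptors; the pentyl that enters carries none, at the same count of carbon atoms.

Going by the values given here, no measured step of this kind exists, so the expected step from compound 1 to compound 3 in this assay is estimated as a 2.0-fold higher number from compound 1 to compound 3 (0.30 log units; within the scatter), a modest loss or none beyond the scatter. Compound 3 is therefore expected to give 800 nM, with a range of 200 nM to 3200 nM.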

Compound 3, half-maximal inhibitory concentration: 80 nM
The estimate for compound 3 lay 10-fold (1.00 log units) above the measured number, outside the stated range (below it).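

Among the compounds shown here, the substituent on the nitrogen on an aromatic ring now proves able to move the read-out: in this assay, pentyl in place of 1-(ethoxycarbonyl)ethyl gives a 5.0-fold lower number from compound 1 to compound 3 (0.70 log units; beyond the scatter), the first step that can be read. The group that leaves carries hydrogen-bond acceptors and the pentyl that enters carries none, so in this one pair inhibition does not require those acceptors at this place. Nothing on record bears on why pentyl gives the lower number, and a single pair sets no trend.

Open, on these data alone, is whether the step belongs to the loss of the ethyl ester or to the plain chain itself: a free carboxylic acid, or an amine at the end of a chain, on this nitrogen would separate the two. Chain length also stays open: butyl or heptyl in place of pentyl would show whether the number in this assay keeps falling, levels off or turns back up as the chain changes.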